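The source may hold more compounds than are shown below. What is called first, only, known or untested is meant among the compounds shown, and "the series" means these compounds.

Working notes on the coumarin-free description of the series: the shared core of compound 1 `COc1ccc2ccc(=O)oc2c1-c1cc(-c2ccc(C)o2)nc(N)n1` carries a 5-methylfuran-2-yl group, and in a functional assay on aorta (Rattus norvegicus, strain Wistar) for inhibition (on this read-out higher numbers stand for weaker inhibition and lower numbers for stronger inhibition), compound 1 gives 1230000 nM, the only single number recorded for it. Compound 2 `COc1ccc2ccc(=O)oc2c1-c1cc(-c2ccccc2)nc(N)n1` bears a phenyl group in the same place and has been run more than once; in this assay compound 2 gives 800000 nM; 1250000 nM (2 entries), and the several entries of compound 2 in this assay, 800000 nM; 1250000 nM (2 entries) shows how far repeat entries of one compound spread here. The values of compound 1 and compound 2 lie within the usual scatter of each other, so the exchange of 5-methylfuran-2-yl for phenyl shows no effect that can be separated from repeat noise.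

Compound 3 `COc1ccc2ccc(=O)oc2c1-c1cc(-c2ccc(C(F)(F)F)cc2)nc(N)n1` has not been measured in this assay. Its structure differs from compound 1 by 4-(trifluoromethyl)phenyl in place of 5-methylfuran-2-yl on an aromatic carbon. Among the compounds with values here, no measured pair covers this exact change, so the size of the step is open; the expectation is a step of no more than the scatter in either direction, since the phenyl analogue compound 2 gives 800000 nM; 1250000 nM (2 entries). Compound 3 is estimated at 1000000 nM, with a range from 350000 nM to 3000000 nM, which corresponds to an expected step of a 1.2-fold lower number from compound 1 to compound 3 (0.09 log units; within the scatter).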

Compound 3, half-maximal inhibitory concentration: 1060000 nM
Estimate against measurement, compound 3: 1.1-fold (0.03 log units) below; measured number inside the range.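

The exchange of 5-methylfuran-2-yl for 4-(trifluoromethyl)phenyl in this assay gives a 1.2-fold lower number from compound 1 to compound 3 (0.06 log units; within the scatter), so even with 10 heavy atoms entering and 6 leaving, and with a five-membered aromatic ring with 1 hetero atom replaced by a six-membered aromatic ring of carbon only, no effect separates from the noise. The trifluoromethyl group on the phenyl ring also leaves no visible mark: compound 3 gives 1060000 nM, a number that falls inside the spread of the repeat entries of compound 2. The three groups now seen on this aromatic carbon, 5-methylfuran-2-yl, phenyl and 4-(trifluoromethyl)phenyl, therefore cannot be ranked, as any difference among them would have to exceed the spread seen for a single compound: the several entries of compound 2 in this assay, 800000 nM; 1250000 nM (2 entries)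

Going by these compounds, all three groups are aromatic rings, so it remains open whether an amine, a carboxylic acid or a longer alkyl chain on this carbon would move the number beyond the scatter. The three compounds also share the rest of the core unchanged, which leaves open how the read-out responds to a change anywhere else, including at the amino group.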